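The source may report more compounds than this note shows. Statements on the series, on what has been measured and on what is new or still open speak of the compounds shown alone.

Three compounds share one core and differ only in the group attached to it. Compound 1 `CCOC(=O)[C@H](CCC(=O)O)NC(=O)c1ccc(Sc2nc3cc(N)cc(N)c3nc2-c2ccccc2)cc1`, compound 2 `COc1cc(CNc2nc3cc(N)cc(N)c3nc2-c2ccccc2)cc(OC)c1OC` and compound 3 `COc1ccc(Sc2nc3cc(N)cc(N)c3nc2-c2ccccc2)cc1` were all tested in a functional assay on SK-OV-3 cells (Homo sapiens) for inhibition, read by sulforhodamine B assay, with a stated time of 48 h; a higher number here means a weaker inhibitor of growth, a lower number a stronger inhibitor of growth. In this assay compound 1 gives 17800 nM, compound 2 gives 5370 nM, and compound 3 gives 33100 nM. Compound 3 thus carries the highest of the three numbers, though its gap to compound 1 lies within the scatter, so the two cannot be ordered; its gap to compound 2 is beyond the scatter.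

Compound 4 `Nc1cc(N)c2nc(-c3ccccc3)c(Sc3ccc(F)cc3)nc2c1` has not yet been measured. It differs from compound 3 in one place: fluoro in place of methoxy on an aromatic carbon. Going by the values given here, no measured pair shows this change, so nothing in the data says which way it goes. The step from compound 3 to compound 4 is expected to be no larger than the scatter, a 1.3-fold lower number from compound 3 to compound 4 (0.12 log units; within the scatter). Compound 4 is therefore expected to give about 25000 nM, within a range from 8000 nM to 80000 nM.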

Compound 4, concentration for 50% growth inhibition: 15800 nM
Compound 4: the middle estimate sits 1.6-fold (0.20 log units) above what was measured; the range from low to high includes it.
By their numbers in this assay, from the lowest: compound 2; then compounds 4, 1 and 3 (each within the scatter of the next, the first and the last beyond it).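

In this assay, going by these compounds alone, replacing methoxy with fluoro, which turns the (4-methoxyphenyl)sulfanyl group into (4-fluorophenyl)sulfanyl, gives a 2.1-fold lower number from compound 3 to compound 4 (0.32 log units; beyond the scatter) as the first step in this set that changes a single place. The step is modest, but it shows that the number can respond to the group on this aromatic carbon, and here the lower number goes with the group of fewer heavy atoms and no hydrogen-bond acceptor. Nothing measured here explains why the number moves.

This single pair cannot tell whether fluoro itself matters or only the loss of methoxy, since compounds with chloro, an amine or a plain hydrogen on this carbon are not among those shown. A carboxylic acid or a longer chain at this place also remains untested in what is shown here.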